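The source may report more compounds than this note shows. Statements on the series, on what has been measured and on what is new or still open speak of the compounds shown alone.

Measured so far in a functional assay on A549 cells (Homo sapiens) for cytotoxicity, with a stated time of 48 h; a higher number here means a weaker inhibitor of growth, a lower number a stronger inhibitor of growth:
compound 1 `Cc1cc(-c2cc(N3C[C@H](O)[C@@H](O)C3)ccc2O)nc(N)n1`: 2000 nM
compound 2 `CN(C)c1cc(-c2cc(N3C[C@H](O)[C@@H](O)C3)ccc2O)nc(N)n1`: "not determined" (no result reported)
compound 3 `Nc1nc(-c2cc(N3C[C@H](O)[C@@H](O)C3)ccc2O)cc(C2CCNCC2)n1`: "not determined" (no result reported)

These three compounds share a core and differ in one group. Only one of them has a usable number. For compound 3, the entry in this assay reads "not determined" (no result reported), so it offers no single number to compare against. The same holds for compound 2, which also reads "not determined" (no result reported).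

The next compound to be tested is compound 4 `CCc1cc(-c2cc(N3C[C@H](O)[C@@H](O)C3)ccc2O)nc(N)n1`. The structural change is ethyl in place of piperidin-4-yl on an aromatic carbon, next to the ring nitrogen.

With no number for compound 3, the size of this step cannot be read from the data. For the measured compounds named here, the only anchor is compound 1 at 2000 nM, so the expectation in this assay is a result that does not differ from that value beyond the usual scatter, in either direction. With a single anchor, the range must stay wide.

The estimate for compound 4 is an expected 2000 nM, with a likely range from 700 nM to 6000 nM.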

Compound 4, concentration for 50% growth inhibition: 3000 nM
Beside the measured number, compound 4's estimate is 1.5-fold (0.18 log units) below it, and the stated range covers the measured number.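

In this assay, going from the methyl of compound 1 to the ethyl of compound 4, on the aromatic carbon next to the ring nitrogen, gives a 1.5-fold higher number from compound 1 to compound 4 (0.18 log units; within the scatter) and the two compounds cannot be told apart. For the compounds shown here, this is the first readable comparison at this position, and it shows that one added carbon on this small chain keeps the result inside the normal spread of repeated measurements. Nothing shown here offers a measured reason for this result.

The steps involving compound 2 and compound 3 cannot be read, with no number for either, so the dimethylamino and piperidin-4-yl groups remain uncompared with methyl and ethyl. Going by these compounds, whether a longer chain such as butyl, or a carboxylic acid, at this position would give a similar number also remains open.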